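A few compounds are considered here, and "the series" means these few. Any claim that something is new, unique, unknown or untested is made for them only; others in the source may bear on it.

Measured so far in an ADME assay on the whole organism (Rattus norvegicus, strain Sprague-Dawley) for pharmacokinetics; a higher number here means that more of the compound sits outside the plasma, a lower number that more of the compound stays in the plasma:
- compound 1 `CC1(C)C[C@H](c2c[nH]c3c(C(N)=O)cc(-c4ccc(F)cc4)cc23)CCS1(=O)=O`: 4.7 L/kg
- compound 2 `NC(=O)c1cc(-c2ccccc2)cc2c(C3CCN(S(=O)(=O)CCCN4CCCC4)CC3)c[nH]c12`: 1 L/kg

Of these two compounds, compound 2 stands lowest at 1 L/kg. Compound 1 gives 4.7 L/kg, and that gap is beyond the scatter. The two compounds differ in more than one place, so their gap gives no direct measure for any single change.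

The next compound is compound 3 `CCS(=O)(=O)N1CCC(c2c[nH]c3c(C(N)=O)cc(-c4ccccc4)cc23)CC1`, which has not yet been measured in this assay. It departs from compound 2 by hydrogen in place of (pyrrolidin-1-yl)methyl on a saturated chain carbon, two bonds along the chain from a sulfonyl sulfur. In words, hydrogen stands in place of (pyrrolidin-1-yl)methyl on a saturated chain carbon, two bonds along the chain from a sulfonyl sulfur. Cut one bond further out, the same difference reads 3-(pyrrolidin-1-yl)propyl to ethyl.

Going by the values given here, no measured step shows what this change does, so any expectation here is loose. The expected step, a 1.3-fold lower number from compound 2 to compound 3 (0.10 log units; within the scatter), is small, leaning slightly towards a lower number and not beyond the scatter. For compound 3 the estimated value is 0.8 L/kg, with an expected range from 0.3 L/kg to 2.2 L/kg.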

Compound 3, volume of distribution at steady state: 1 L/kg
The estimate for compound 3 lay 1.3-fold (0.10 log units) below the measured number, within the range that was stated.
By their numbers in this assay, from the lowest: compounds 2 and 3 (each within the scatter of the next); then compound 1.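

In this assay, going by these compounds alone, placing hydrogen in place of (pyrrolidin-1-yl)methyl on a saturated chain carbon, two bonds along the chain from a sulfonyl sulfur, gives no change at the digits printed from compound 2 to compound 3 (within the scatter) and so provides the first single-place comparison. The change takes away a five-membered non-aromatic ring with 1 hetero atom, yet this read-out does not separate the 3-(pyrrolidin-1-yl)propyl group from the ethyl group on the sulfonyl, so at this position the (pyrrolidin-1-yl)methyl group leaves no mark beyond the scatter in this pair. Nothing available here explains this result.

On these data alone, this is one pair on one shared core, so whether the same holds on another core, including that of compound 1, remains open. Also open, as far as these compounds go, is whether other groups at this place, such as a carboxylic acid, a morpholine at the end of the chain or a longer chain carrying a primary amine, would likewise stay within the scatter of compound 2 or would move the number beyond it.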